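The compounds below may be only part of what the source reports. "The series", "measured", "known", "first", "only" and "open" are said of these compounds alone.

In an ADME assay on MT4 cells (Homo sapiens) for cytotoxicity, read by MTT assay (a higher number here means that more compound is tolerated, a lower number that less compound is tolerated), compound 1 `O=C(CSc1nncnc1-c1ccccc1Cl)Nc1ccccc1Br` gives 73000 nM, compound 2 `O=C(CSc1nncnc1-c1ccccc1Cl)Nc1ccccc1F` gives 98000 nM and compound 3 `O=C(CSc1nncnc1-c1ccccc1Cl)Nc1ccccc1[N+](=O)[O-]` gives 63000 nM, so compound 1 stands within the scatter of both others. Compound 4 `CCOC(=O)c1ccc(NC(=O)CSc2nncnc2-c2ccccc2Cl)c(Br)c1` keeps everything in compound 1 and adds one group: ethoxycarbonyl in place of hydrogen on an aromatic carbon. Among the measured compounds shown here, three measured steps bear on this only indirectly: a 1.3-fold higher number from compound 1 to compound 2 (0.13 log units; within the scatter), a 1.2-fold lower number from compound 1 to compound 3 (0.06 log units; within the scatter) and a 1.6-fold lower number from compound 2 to compound 3 (0.19 log units; within the scatter). Each exchanges one group on an aromatic carbon, and none of them tests ethoxycarbonyl. With no measured step beyond the scatter, no change beyond the scatter is expected in this assay. The expected step is a 1.2-fold lower number from compound 1 to compound 4 (0.09 log units; within the scatter). The estimate for compound 4 is 60000 nM, with an expected range of 25000 nM to 120000 nM.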

Compound 4, half-maximal cytotoxic concentration: 69000 nM
Compound 4: middle estimate off by 1.2-fold (0.06 log units), on the low side; the measured number falls inside the stated range.
By their numbers in this assay, from the lowest: compounds 3, 4, 1 and 2 (each within the scatter of the next).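

The earlier steps shown here only exchanged one group on an aromatic carbon, whereas compound 4 fills a hydrogen-bearing carbon, meta to a bromo group and para to a large group. In this assay, adding ethoxycarbonyl, with its 5 heavy atoms, gives a 1.1-fold lower number from compound 1 to compound 4 (0.02 log units; within the scatter), so this carbon accepts the group without a change beyond the scatter. No measurement available here accounts for this result. As far as these compounds go, whether a carboxylic acid or an amine on this carbon would also stay within the scatter of compound 1 remains open. Also open, from the compounds shown here alone, is whether ethoxycarbonyl behaves alike with fluoro or nitro in place of bromo.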